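Compound 3 to Compound 4: One Aryl Group Exchanged

The source may hold more compounds than are shown below. What is called first, only, known or untested is meant among the compounds shown, and "the series" means these compounds.

This piece concerns a small group of compounds tested in an ADME assay on cells (Epithelial cell, Homo sapiens) for antiproliferative activity, read by MTT assay, with a stated time of 48 h; a lower number here means a stronger inhibitor, a higher number a weaker inhibitor. Compound 1 `COc1ccc(OC)c([C@@H]2[C@H](OC)C(=O)N2C/C(C#N)=C/c2ccccc2)c1` gives only a limit in this assay, > 100000 nM. Compound 2 `CO[C@@H]1C(=O)N(C/C(C#N)=C/c2ccccc2)[C@@H]1c1ccc(Cl)cc1Cl` likewise gives only a limit, > 100000 nM. For the measured compounds named here, compound 3 `COC(=O)/C(=C/c1ccccc1)CN1C(=O)[C@@H](OC)[C@H]1c1cccc(F)c1` is the only one with a measured number, 38500 nM, which marks it as a weak inhibitor. Going by the values given here, that lone number is the sole point of comparison; the rest of the data are the limit of > 100000 nM in this assay, at which 2 of the 3 values shown sit.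

Compound 4 `COC(=O)/C(=C/c1ccccc1)CN1C(=O)[C@@H](OC)[C@H]1c1ccc(OC)cc1` has not yet been measured. It differs from compound 3 in one place: 4-methoxyphenyl in place of 3-fluorophenyl on a saturated ring carbon. Among the compounds with values here, no step between two measured compounds is available, so there is no measured guide to how a change at this saturated ring carbon shifts the result. All three compounds shown sit at weak or unmeasurably weak levels, so a large gain is not expected. The expected step of a 1.4-fold higher number from compound 3 to compound 4 (0.15 log units; within the scatter) is none beyond the scatter, with a slight lean toward weaker. Compound 4 is therefore estimated at 55000 nM, with a range from 15000 nM to 150000 nM, and it may well return only a limit.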

Compound 4, half-maximal inhibitory concentration: "not toxic" (no number reported)
The entry for compound 4 holds no number, and the estimate cannot be compared.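

In this assay, for the compounds shown here, compound 4 is recorded only as "not toxic", without a number, so no step from compound 3 to compound 4 can be read. The compounds shown leave open how exchanging 3-fluorophenyl for 4-methoxyphenyl shifts the result, and much of the data offers only a limit, not a number: the limit of > 100000 nM in this assay, at which 2 of the 4 values shown sit.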